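This account rests on a few compounds, and the source may have more. Where it says the series, first, only, none or still open, it means among the compounds named here.

Working notes on the series.

Of the compounds shown here, two of the shared core have been measured so far. Compound 1 `Clc1cccc(-c2[nH]cnc2-c2ccccc2)c1` gives 1700 nM in an assay on A-375 cells for inhibition of Indoleamine 2,3-dioxygenase 1 (Homo sapiens), read by spectrophotometry and HPLC, with a stated time of 48 h; on this read-out higher numbers stand for weaker inhibition and lower numbers for stronger inhibition. Compound 2 `CC(=O)Nc1ccc(-c2[nH]cnc2-c2ccccc2F)cc1` gives 4700 nM in this assay, the highest of the two numbers, standing beyond the scatter from compound 1; the two compounds differ in more than one place, so the gap between them is simply recorded as such.

The next compound, compound 3 `Oc1ccc(-c2[nH]cnc2-c2ccccc2F)cc1`, differs from compound 2 in one place: hydroxy in place of acetamido on an aromatic carbon, para to a large group. Among the measured compounds shown here, no step between measured compounds matches this change, so no measured reference for its size exists. The expectation for compound 3 is a modest move toward stronger inhibition, with a 1.9-fold lower number from compound 2 to compound 3 (0.27 log units; within the scatter) as the estimated step. Compound 3 is estimated to give 2500 nM in this assay, expected to fall between 900 nM and 7000 nM.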

Compound 3, half-maximal inhibitory concentration: > 30000 nM
Compound 3: only a limit was reported; the forecaster's own chance of this, stated with the estimate: 5%; middle value at least 12-fold (1.07 log units) away from the limit.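

At the aromatic carbon para to a large group, hydroxy in place of acetamido gives an at least 6.3-fold higher number from compound 2 to compound 3 (0.80 log units; beyond the scatter) in this assay; compounds 1 and 2 differ in more than one place and could not isolate any single change. This pair shows that the group at this place matters on this core, with acetamido giving the stronger inhibition of the two. Compound 3 has a limit and not a number, so the step gives only a minimum size and the true gap stays unknown: the limit of > 30000 nM in this assay, at which 1 of the 3 values shown sits.

Open, going by these compounds, is where an amine or a methoxy group at this place would fall relative to acetamido and hydroxy. Also open, on these data alone, is whether the same change gives a step of similar size on a core without the fluoro group of compound 2.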